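The compounds below may be only part of what the source reports. "The series", "measured", "known", "first", "only" and "open" are said of these compounds alone.

Values in a functional assay on HeLa cells (Homo sapiens) for inhibition, read by CCK-8 assay, with a stated time of 48 h; on this read-out higher numbers stand for weaker inhibition and lower numbers for stronger inhibition:
- compound 1 `COc1cc(-c2ccnc3cc(-c4ccc(Cl)cc4)nn23)cc(OC)c1OC`: 1490 nM
- compound 2 `COc1cc(-c2ccnc3cc(-c4cccc(C#N)c4)nn23)cc(OC)c1OC`: > 10000 nM
- compound 3 `COc1cc(-c2ccnc3cc(-c4ccccc4)nn23)cc(OC)c1OC`: 458 nM

Compound 2 stands at > 10000 nM, which is a limit of the assay and not a number. Compound 3, at 458 nM, holds the lower of the two actual numbers, and the nearest is compound 1 at 1490 nM.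

The next change starts from compound 3. Compound 4 `COc1cc(-c2ccnc3cc(-c4ccc5c(ccn5C)c4)nn23)cc(OC)c1OC` carries 1-methyl-1H-indol-5-yl in place of phenyl on an aromatic carbon.

Within the data shown here, two measured steps bear on this position. The first is modest, a 3.3-fold lower number from compound 1 to compound 3 (0.51 log units; beyond the scatter). The second is large, an at least 21-fold lower number from compound 2 to compound 3 (1.33 log units; beyond the scatter). Both show the plain phenyl with the lower number, and this would warn against expecting a gain from a larger group. Neither step brings in a second ring, however, so neither gives a reliable size or direction for this replacement. In this assay, no step beyond the scatter is therefore expected as the central case, with wide uncertainty on both sides. The estimated step is a 1.8-fold lower number from compound 3 to compound 4 (0.26 log units; within the scatter). The value expected for compound 4 is 250 nM. The expected range runs from 25 nM to 2500 nM.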

Compound 4, half-maximal inhibitory concentration: 19 nM
Compound 4: the middle estimate sits 13-fold (1.12 log units) above what was measured; measured number below the stated range.
By their numbers in this assay, from the lowest: compound 4; then compound 3; then compound 1. At a limit, above all of these: compound 2.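

In this assay, the earlier replacements of phenyl at this position, 4-chlorophenyl and 3-cyanophenyl, both kept a single six-membered ring and both gave higher numbers, whereas 1-methyl-1H-indol-5-yl is the first group shown to go below phenyl: a 24-fold lower number from compound 3 to compound 4 (1.38 log units; beyond the scatter). Against 4-chlorophenyl the same group gives a 78-fold lower number from compound 1 to compound 4 (1.89 log units; beyond the scatter), so added size alone does not set the direction here: compounds 1 and 2 carry substituted phenyls and go against any simple trend with size, while the fused two-ring group in compound 4 gives the lowest number of the series. Against 3-cyanophenyl the step is an at least 520-fold lower number from compound 2 to compound 4 (2.72 log units; beyond the scatter), with compound 2 standing at a limit and not at a number: the limit of > 10000 nM in this assay, at which 1 of the 4 values shown sits.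

Still open is which part of the new group carries the gain, since the compounds shown do not separate the methyl on the ring nitrogen, the ring nitrogen itself and the second ring, as 1H-indol-5-yl or 2-naphthyl would. Also open, going by these compounds, is whether 1-methyl-1H-indol-6-yl, or an amine or a carboxylic acid on the indole, would hold the low number of compound 4.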